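Swapping an Ethyl for a Bromo Group on the Side Ring

The source may hold more compounds than are shown below. What is called first, only, known or untested is meant among the compounds shown, and "the series" means these compounds.

In a functional assay (muscle tissue) with Cavia porcellus as the target (on this read-out lower numbers stand for an effect already at smaller amounts and higher numbers for an effect only at larger amounts of compound), compound 3 `CCc1ccccc1C1C(C(=O)OC)=C(C)N=C(C)/C1=C(\O)OC` gives 6.46 nM, the lowest of the three measured numbers. Compound 2 `COC(=O)C1=C(C)N=C(C)/C(=C(\O)OC)C1c1cccc(C)c1` gives 110 nM and compound 1 `COC(=O)C1=C(C)N=C(C)/C(=C(\O)OC)C1c1cccc(N)c1` gives 2000 nM. The measured steps of an 18-fold lower number from compound 1 to compound 2 (1.26 log units; beyond the scatter), a 310-fold lower number from compound 1 to compound 3 (2.49 log units; beyond the scatter) and a 17-fold lower number from compound 2 to compound 3 (1.23 log units; beyond the scatter) each come from altering the group on the side ring, and all are large. Compound 4 `COC(=O)C1=C(C)N=C(C)/C(=C(\O)OC)C1c1ccccc1Br` differs from compound 3 by bromo in place of ethyl on an aromatic carbon. Among the compounds with values here, no measured step exchanges an ethyl for a bromo, so the earlier steps show only that this ring responds strongly to change, not in which direction this one will go. The step of a 1.2-fold higher number from compound 3 to compound 4 (0.09 log units; within the scatter) is expected to stay within the scatter. Compound 4 is therefore estimated at 8 nM, ranging from 2 nM to 40 nM.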

Compound 4, half-maximal effective concentration: 7.59 nM
Estimate against measurement, compound 4: 1.1-fold (0.02 log units) above, and the stated range covers the measured number.
By their numbers in this assay, from the lowest: compounds 3 and 4 (each within the scatter of the next); then compound 2; then compound 1.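

In this assay, the step of a 1.2-fold higher number from compound 3 to compound 4 (0.07 log units; within the scatter) stays within the scatter, so at this place on the side ring a bromo, with one heavy atom, cannot be told apart from an ethyl, with two. The bromo also gives the large steps of a 14-fold lower number from compound 2 to compound 4 (1.16 log units; beyond the scatter) and a 260-fold lower number from compound 1 to compound 4 (2.42 log units; beyond the scatter), matching what the ethyl showed against these two compounds. Nothing available explains why the two groups match. From the compounds shown here alone, whether a methoxy or a nitro group at this place would give a similar number remains open.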